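A methyl in place of hydrogen on an aromatic nitrogen

This account rests on a few compounds, and the source may have more. Where it says the series, first, only, none or still open, it means among the compounds named here.

In an in vivo ADME assay on the whole organism (plasma, Rattus norvegicus) for protein binding, at a dose of 5 mg/kg by the oral route, compound 1 (`CC(=O)Nc1cc(-c2c(Nc3cc[nH]n3)nc3cccnn23)nc(C)n1`) stands at 94.4% and compound 2 (`CC(=O)Nc1cc(-c2c(Nc3ccn(C)n3)nc3ccccn23)nc(C)n1`) at 94.4% with the two level at the digits shown. Compound 3 (`CC(=O)Nc1cc(-c2c(Nc3ccn(C)n3)nc3cccnn23)nc(C)n1`) has not yet been measured. It differs from compound 1 by methyl in place of hydrogen on an aromatic nitrogen with 1H-pyrazol-3-yl becoming 1-methyl-1H-pyrazol-3-yl. Going by the values given here, no measured pair shows this change alone, so the step (a 1.1-fold lower unbound fraction from compound 1 to compound 3 (0.05 log units; within the scatter)) is expected to stay within the scatter, with no direction favoured. Compound 3 is expected to give 95% (estimated range 91.5% to 97.5%).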

Compound 3, plasma protein binding: 96.7%
Compound 3: middle estimate off by 1.5-fold (0.18 log units) (unbound fraction), on the high side, and the stated range covers the measured number.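

In this assay, going by these compounds alone, methyl in place of hydrogen on the aromatic nitrogen gives a 1.7-fold lower unbound fraction from compound 1 to compound 3 (0.23 log units; within the scatter) and this is the first reading of that change alone. At this position, then, the single added carbon leaves plasma protein binding within the usual scatter of the measurement. Nothing available explains the reading. 
Going by these compounds, whether a longer chain, such as propyl, or a chain ending in an amine or a carboxylic acid on this nitrogen would carry the binding beyond the scatter stays open. So does whether the same methyl would read alike on a different core.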